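The source may hold more compounds than are shown below. What is called first, only, known or untested is meant among the compounds shown, and "the series" means these compounds.

Among the measured compounds shown here, compound 2, `CNC(=O)NCc1ccccc1-c1ccc(CN2C(=O)[C@H](NC(=O)CC(C)(C)N)CCc3ccccc32)cc1`, gives the lower of the two numbers so far recorded in a functional assay (Pituitary gland cell) with Rattus norvegicus as the target; a lower number here means that less compound is needed, a higher number that more compound is needed for the effect: compound 2 gives 6 nM, whereas compound 1, `CNC(=O)Nc1ccccc1-c1ccc(CN2C(=O)[C@H](NC(=O)CC(C)(C)N)CCc3ccccc32)cc1`, gives 50 nM. For the measured compounds named here, the one measured step, an 8.3-fold lower number from compound 1 to compound 2 (0.92 log units; beyond the scatter), came from a change on the biaryl end of the molecule, where a ((methylcarbamoyl)amino)methyl group replaced a (methylcarbamoyl)amino group on an aromatic carbon.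

Compound 3, `CNC(=O)NCc1ccccc1-c1ccc(CN2C(=O)[C@H](NC(=O)C(C)(C)N)CCc3ccccc32)cc1`, is compound 2 with a different change: 1-amino-1-methylethyl in place of 2-amino-2-methylpropyl on a carbonyl carbon. This shortens the side chain on the amide by one carbon while keeping the amine. Going by the values given here, no measured step touches this part of the molecule, so the step from compound 1 to compound 2 does not speak to it, and there is no basis for predicting a direction.

Compound 3 is therefore expected to stay near compound 2, with the step of a 1.7-fold higher number from compound 2 to compound 3 (0.22 log units; within the scatter) estimated to lie within the scatter. The estimate for compound 3 in this assay is 10 nM, with a range from 2 nM to 60 nM.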

Compound 3, concentration for half-maximal effect: 1 nM
Compound 3: the middle estimate sits 10-fold (1.00 log units) above what was measured; measured number outside the range, below it.
By their numbers in this assay, from the lowest: compound 3; then compound 2; then compound 1.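

The amide side chain, untouched by the earlier step, turns out to matter in this assay: 1-amino-1-methylethyl in place of 2-amino-2-methylpropyl on a carbonyl carbon gives a 6.0-fold lower number from compound 2 to compound 3 (0.78 log units; beyond the scatter). The entering group has 4 heavy atoms against 5 in the group it replaces, with the same counts of hydrogen-bond donors and acceptors, so a small change at this position is enough to move the number beyond the scatter. Nothing available accounts for the size or direction of this step.

The compounds shown leave open whether the amine itself is needed, as a hydroxyl group or a methyl group in its place would test. They also leave open whether a cyclopropane ring joining the two methyl groups would fit this position, and whether the same change would act alike on compound 1.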